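The source may hold more compounds than are shown below. What is called first, only, known or untested is meant among the compounds shown, and "the series" means these compounds.

In an ADME assay on CCRF-HSB-2 cells (Homo sapiens) for cytotoxicity, with a stated time of 7 days (on this read-out higher numbers stand for lower toxicity in this test and lower numbers for higher toxicity in this test), compound 3 (`Nc1nc(N2CCCC2)c2ncn(/C=C3/CC3(CO)CO)c2n1`) has only > 20000 nM, which is a limit and not a number. Compound 2 (`Nc1nc(NCc2ccccc2)c2ncn(/C=C3/CC3(CO)CO)c2n1`) likewise has only a limit, > 20000 nM. Among the compounds with values here, the one true number comes from compound 1 (`CCCSc1nc(N)nc2c1ncn2/C=C1/CC1(CO)CO`), at 98000 nM, so all three compounds show low toxicity in this test.

The next compound, compound 4 (`CCCNc1nc(N)nc2c1ncn2/C=C1/CC1(CO)CO`), has propylamino in place of pyrrolidin-1-yl on an aromatic carbon of the shared core: propylamino in place of pyrrolidin-1-yl on an aromatic carbon. The closed ring thus gives way to an open chain.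

Within the data shown here, three measured steps bear on this change, all at the same aromatic carbon: a step that the limit leaves unreadable from compound 1 to compound 3, a step that the limit leaves unreadable from compound 1 to compound 2 and a step that the two limits leave unreadable from compound 2 to compound 3. None of them has a size that can be read, and the evidence consists largely of the limit of > 20000 nM in this assay, at which 2 of the 3 values shown sit. Among the measured compounds shown here, compound 1, which also carries a propyl chain, gives the only numerical guide at 98000 nM, so compound 4 is expected to remain weakly toxic. Another limit is quite possible for compound 4. The estimated change is a step that the limit leaves unreadable from compound 3 to compound 4, and no direction can be firmly expected for it. For compound 4, the estimated value in this assay is 40000 nM, with an expected range from 12000 nM to 120000 nM.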

Compound 4, half-maximal cytotoxic concentration: > 20000 nM
Compound 4: no number, only a limit; the forecaster's own chance of this, stated with the estimate: 55%; the middle value is on the limit's open side.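

In this assay compound 4 gives > 20000 nM, which is a limit and not a number, so its steps from compound 1, compound 2 and compound 3 cannot be read. How far propylamino, pyrrolidin-1-yl and benzylamino differ in toxicity in this test stays open, and the comparison stops at one shared boundary: the limit of > 20000 nM in this assay, at which 3 of the 4 values shown sit.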